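A few compounds are considered here, and "the series" means these few. Any claim that something is new, unique, unknown or untested is made for them only; others in the source may bear on it.

Of the compounds shown here, three from one family have been tested in a functional assay on SK-OV-3 cells (Homo sapiens) for cytotoxicity, read by sulforhodamine B assay, with a stated time of 48 h, tested at 100 uM (a lower number here means a stronger effect, a higher number a weaker effect of the compound at the concentration tested), and a fourth is waiting. Compound 3 `COc1ccc(-c2cc(/C=C/C(=O)c3ccc(N)cc3)[nH]n2)cc1OC` gives -99% in this assay. Compound 1 `COc1cc(-c2cc(/C=C/C(=O)c3ccc(N)cc3)[nH]n2)cc(OC)c1OC` differs from compound 3 by one change, (methoxy in place of hydrogen on an aromatic carbon), and that change moved the read-out by a number 1 percentage points higher from compound 3 to compound 1 (within the scatter). Compound 2 `COc1ccc(C(=O)/C=C/c2cc(-c3cc(OC)c(OC)c(OC)c3)n[nH]2)cc1OC` differs from compound 1 by a change at the carbonyl carbon, 3,4-dimethoxyphenyl in place of 4-aminophenyl, and that move gave no change at the digits printed from compound 1 to compound 2 (within the scatter); in this assay compound 2 gives -98%, and compound 1 gives -98%. The difference between the cores of compound 2 and compound 3 is not broken down here; their two values sit close together.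

Compound 4 `COc1cc(C(=O)/C=C/c2cc(-c3cc(OC)c(OC)c(OC)c3)n[nH]2)cc(OC)c1OC` is the unmeasured one. Among the compounds with values here, it differs from compound 2 by methoxy in place of hydrogen on an aromatic carbon, which is the same change as the one from compound 3 to compound 1, at the same kind of place. Because a number 1 percentage points higher from compound 3 to compound 1 (within the scatter) was a small move, the step from compound 2 to compound 4 is expected to be small as well, estimated as no change at the digits printed from compound 2 to compound 4 (within the scatter). Since the three measured values already lie close together near the end of the scale, compound 4 is expected to give about -98% in this assay, with the estimate running from -100% to -90%.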

Compound 4, a percentage reported as activity, at one concentration (the size of the read-out at that concentration, not a potency): -100%
Beside the measured number, compound 4's estimate is 2 percentage points above it; low and high end bracket the measured number.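

Putting methoxy in place of hydrogen on the aromatic carbon gave a number 2 percentage points lower from compound 2 to compound 4 (within the scatter) in this assay. Set beside the earlier case, the change looks alike on the two cores as far as this read-out can tell: the same change on two cores in this assay, a number 1 percentage points higher (within the scatter) from compound 3 to compound 1 and a number 2 percentage points lower (within the scatter) from compound 2 to compound 4, 3 percentage points apart, within the scatter of two such steps. This shows that, in these two pairs, the change carried from one core to the other without a step beyond the usual scatter, but it does not show that the methoxy group is without effect or that the same would hold on any other core, since the read-out comes from one concentration, gives no potency, and the four values lie close together near the end of the scale.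

The compounds shown leave open what other groups would do at this place on the ring, such as a hydroxyl, an ethoxy group or a carboxylic acid, since methoxy is the only group that enters here. They also leave open whether the two steps would stay this small at lower concentrations, where the compounds might spread apart into stronger and weaker effects at the concentration tested.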